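Iodo-to-hydrogen step carried from one core to another

The compounds below may be only part of what the source reports. "The series", "measured", "known", "first", "only" and "open" are said of these compounds alone.

Compound 1 `O=C1O/C(=C\Cn2cc(I)c(=O)[nH]c2=O)C(OCc2ccccc2)=C1OCc1ccccc1` in an ADME assay on L1210/0 cells (Mus musculus) for cytotoxicity, with a stated time of 48 h (a higher number here means a weaker inhibitor, a lower number a stronger inhibitor), gives 7500 nM. Compound 2 `O=C1O/C(=C\Cn2ccc(=O)[nH]c2=O)C(OCc2ccccc2)=C1OCc1ccccc1` gives 12900 nM in this assay. The two differ by hydrogen in place of iodo on an aromatic carbon, and the measured step is a 1.7-fold higher number from compound 1 to compound 2 (0.24 log units; within the scatter). Compound 3 `O=c1[nH]c(=O)n([C@@H]2CCC[C@H]2CO)cc1I` carries a different core; the difference between the two cores is not broken down here. In this assay compound 3 gives only a limit, > 200000 nM. Compound 4 `O=c1ccn([C@@H]2CCC[C@H]2CO)c(=O)[nH]1` is not yet measured in this assay; it differs from compound 3 by hydrogen in place of iodo on an aromatic carbon. Within the data shown here, this is the same kind of change as the one from compound 1 to compound 2, though the surroundings are not described in identical words: the ring carbon in compound 3 is meta to a group of 7 heavy atoms, whereas in compound 1 it is meta to a large group. Because the step of a 1.7-fold higher number from compound 1 to compound 2 (0.24 log units; within the scatter) stays within the scatter, and because compound 3 already stands at the limit of > 200000 nM in this assay, at which 1 of the 3 values shown sits, the step from compound 3 to compound 4 is expected to be a step that the limit leaves unreadable from compound 3 to compound 4. Compound 4 is therefore estimated at 300000 nM, with a range from 150000 nM to 1000000 nM, and most probably the assay will again report only a limit.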

Compound 4, half-maximal inhibitory concentration: > 200000 nM
Compound 4 ended at the assay's limit; the forecaster's own chance of this, stated with the estimate: 85%; the middle value is on the limit's open side.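

Among these compounds, no step from compound 3 to compound 4 can be read in this assay, because each of the two compounds gives only a limit and not a number: the limit of > 200000 nM in this assay, at which 2 of the 4 values shown sit. The compounds shown leave open what size, if any, the change of iodo to hydrogen has on the core of compound 3.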